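The compounds below may be only part of what the source reports. "The series", "measured", "known", "first", "only" and "open" are said of these compounds alone.

Measured so far in an ADME assay on A549 cells (Homo sapiens) for cytotoxicity, read by MTT assay; on this read-out higher numbers stand for lower toxicity in this test and lower numbers for higher toxicity in this test:
- Compound 1 `C=CCN(c1ccccc1C)S(=O)(=O)c1cc(Cl)ccc1Cl`: compound 1 gives > 5000 nM, a limit of the assay.
- Compound 2 `CCN(c1ccccc1Cl)S(=O)(=O)c1cc(Cl)ccc1Cl`: compound 2 gives > 5000 nM, a limit of the assay.
- Compound 3 `C=CCN(c1ccc(Cl)cc1C)S(=O)(=O)c1cc(Cl)ccc1Cl`: compound 3 gives > 5000 nM, a limit of the assay.

Compound 3 therefore stands where every measured compound stands, since (the limit of > 5000 nM in this assay, at which 3 of the 3 values shown sit). Going by the values given here, the step that the two limits leave unreadable from compound 1 to compound 3 cannot be read, and no other measured step exists. Compound 4 `Cc1cc(Cl)ccc1N(CCO)S(=O)(=O)c1cc(Cl)ccc1Cl` differs from compound 3 by hydroxymethyl in place of vinyl on a saturated chain carbon bound to a sulfonamide nitrogen. Among the compounds with values here, no measured step bears on this change, so no size can be drawn from the data; the three limits only show that none of the measured compounds revealed toxicity within the tested range. The step is expected to be a step that the limit leaves unreadable from compound 3 to compound 4, with a limit again the most likely outcome. Compound 4 is expected to give 9000 nM, within 3000 nM to 40000 nM.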

Compound 4, half-maximal cytotoxic concentration: > 5000 nM
Compound 4: no number, only a limit; the forecaster's own chance of this, stated with the estimate: 80%; the middle value does not contradict the limit.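

Compound 3 and compound 4 both give only a limit, so the step between them cannot be read: the limit of > 5000 nM in this assay, at which 4 of the 4 values shown sit.

The compounds shown leave open at what concentration, if any, each becomes toxic to these cells, and whether changing allyl to 2-hydroxyethyl alters that concentration.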